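Swapping cyano for fluoro in a cell toxicity test

A few compounds are considered here, and "the series" means these few. Any claim that something is new, unique, unknown or untested is made for them only; others in the source may bear on it.

Of the compounds shown here, two have been measured so far in an ADME assay on MT4 cells (Homo sapiens) for cytotoxicity, read by MTT assay, with a stated time of 5 days (a lower number here means that less compound is tolerated, a higher number that more compound is tolerated), for the concentration at which they harm cells. Compound 1 `COc1cc2nc(Nc3ccc(C#N)cc3)nc(Nc3c(Cl)cc(/C=C/C#N)cc3Cl)c2cc1OC` gives 9920 nM as its reading. Compound 2 `COc1cc2nc(SCC(=O)Nc3ccc(C#N)cc3)nc(Nc3c(C)cc(/C=C/C#N)cc3C)c2cc1OC` gives > 227000 nM as its reading, and that is a limit of the assay, not a number. Compound 2 therefore stands at the limit of > 227000 nM in this assay, at which 1 of the 2 values shown sits, and has no exact position on the scale.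

Compound 3 `COc1cc2nc(SCC(=O)Nc3ccc(F)cc3)nc(Nc3c(C)cc(/C=C/C#N)cc3C)c2cc1OC` keeps all of compound 2 except one group. The change fluoro in place of cyano on an aromatic carbon puts fluoro in place of cyano on an aromatic carbon, para to a large group, so that 4-cyanophenyl becomes 4-fluorophenyl. Within the data shown here, no measured pair of compounds shows this change on its own, so any forecast here is loose. The estimated step of an at least 1.7-fold lower number from compound 2 to compound 3 (0.24 log units; that floor lies within the scatter) is expected to be modest and to point toward a lower number, and the reading may again be only a limit. For compound 3 the estimate is 130000 nM as a middle value, with an expected range from 30000 nM to 280000 nM around it.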

Compound 3, half-maximal cytotoxic concentration: >= 150000 nM
Compound 3 ended at the assay's limit; the forecaster's own chance of this, stated with the estimate: 55%; middle value at least 1.1-fold (0.06 log units) away from the limit.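

Among these compounds, compound 2 and compound 3 both gave limits of the assay rather than numbers in this assay, so no step between them can be read. Going by these compounds, what stays open is whether going from 4-cyanophenyl to 4-fluorophenyl changes the concentration the cells tolerate at all and, if it does, in which direction and by how much.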